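A few compounds are considered here, and "the series" means these few. Any claim that something is new, unique, unknown or untested is made for them only; others in the source may bear on it.

Working notes on the series.

Compound 1 `N#Cc1c(-c2ccccc2)nc(SCC(=O)Nn2c(COc3ccc(Cl)cc3Cl)nc3ccccc3c2=O)[nH]c1=O` is the reference point. In a functional assay on the whole organism (strain albino) for inhibition, with Rattus norvegicus as the target, read by paw edema, with a stated time of 1 h, at a dose of 100 mg/kg by the oral route (on this read-out lower numbers stand for less inhibition and higher numbers for more inhibition at the one dose given (going by the name of the read-out)), compound 1 gives 81.8%. Compound 2 `N#Cc1c(-c2ccc(Cl)cc2)nc(SCC(=O)Nn2c(COc3ccc(Cl)cc3Cl)nc3ccccc3c2=O)[nH]c1=O` carries the change (chloro in place of hydrogen on an aromatic carbon). In this assay, among the measured compounds shown here, compound 2 gives 63.6%, and the step of a number 18.2 percentage points lower from compound 1 to compound 2 (beyond the scatter) is the only measured step for this change so far.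

Compound 3 `N#Cc1c(Nc2ccccc2)nc(SCC(=O)Nn2c(COc3ccc(Cl)cc3Cl)nc3ccccc3c2=O)nc1-c1ccc(O)cc1` has a different core; the difference between the two cores is not broken down here. In this assay compound 3 gives 90.9%, a number that sits near that of compound 1 and above that of compound 2.

Compound 4 `N#Cc1c(Nc2ccc(Cl)cc2)nc(SCC(=O)Nn2c(COc3ccc(Cl)cc3Cl)nc3ccccc3c2=O)nc1-c1ccc(O)cc1` is not yet measured. It relates to compound 3 by chloro in place of hydrogen on an aromatic carbon, the same change as from compound 1 to compound 2, the place being described in the same words; cut one bond further out it reads anilino to (4-chlorophenyl)amino. For the measured compounds named here, with only one measured instance of this change, the expectation for compound 4 rests on compound 1 and compound 2 with their step of a number 18.2 percentage points lower from compound 1 to compound 2 (beyond the scatter), and a step of similar size is expected, a number 17.9 percentage points lower from compound 3 to compound 4 (beyond the scatter). Compound 4 is therefore estimated at 73%, expected to fall between 56% and 88%.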

Compound 4, a percentage reported as inhibition, in the whole organism at one dose (the size of the read-out at that dose, not a potency): 72.7%
For compound 4 the middle estimate is 0.3 percentage points above the measured one, within the range that was stated.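

In this assay, the change from anilino to (4-chlorophenyl)amino gives a number 18.2 percentage points lower from compound 3 to compound 4 (beyond the scatter). Set beside the earlier step, the chloro-for-hydrogen change carries across the two cores without a discernible difference in size: the same change on two cores in this assay, a number 18.2 percentage points lower (beyond the scatter) from compound 1 to compound 2 and a number 18.2 percentage points lower (beyond the scatter) from compound 3 to compound 4, 0 percentage points apart, within the scatter of two such steps This shows agreement for these two matched pairs only, at a single dose and time; it gives no rule for other cores, does not explain the drop, and says nothing about potency.

At this place the compounds shown carry only hydrogen or chloro, so the effect of a fluoro, a methoxy group, an amine or a carboxylic acid there remains open. Also open, as far as these compounds go, is whether the step would keep its size on a third core, or with chloro at another place on the ring.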